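From Methoxycarbonyl to Cyano at the Assay Limit

This account rests on a few compounds, and the source may have more. Where it says the series, first, only, none or still open, it means among the compounds named here.

In a functional assay on Caco-2 cells (Homo sapiens) for inhibition, read by sulforhodamine B assay, with a stated time of 48 h (on this read-out lower numbers stand for stronger inhibition and higher numbers for weaker inhibition), compound 1 (`COC(=O)[C@H]1C[C@@H](c2coc3ccccc3c2=O)N(c2ccccc2)O1`) gives > 60000 nM, which is a limit and not a number. Compound 2 (`COC(=O)[C@H]1C[C@@H](c2coc3ccc(Cl)cc3c2=O)N(c2ccccc2)O1`) gives > 60000 nM, which is also a limit. The chloro in place of hydrogen on an aromatic carbon that separates them is thus a step that the two limits leave unreadable from compound 1 to compound 2. Both compounds rest on the same evidence: the limit of > 60000 nM in this assay, at which 2 of the 2 values shown sit. Compound 2 therefore offers a limit, not a number, as the starting point.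

Compound 3 (`N#C[C@H]1C[C@@H](c2coc3ccc(Cl)cc3c2=O)N(c2ccccc2)O1`) has cyano in place of methoxycarbonyl on a saturated ring carbon, next to the ring oxygen: cyano in place of methoxycarbonyl on a saturated ring carbon. Within the data shown here, no measured step involves this group. Among the measured compounds shown here, the one available step, a step that the two limits leave unreadable from compound 1 to compound 2, concerns a different change and has no readable size. No step beyond the usual scatter can therefore be expected in this assay, in either direction, and another limit is the likeliest outcome. The expected change is a number no higher from compound 2 to compound 3 (the limit leaves the size open). Compound 3 is estimated at 60000 nM, with an expected range from 25000 nM to 120000 nM.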

Compound 3, half-maximal inhibitory concentration: 39000 nM
Estimate against measurement, compound 3: 1.5-fold (0.19 log units) above; low and high end bracket the measured number.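

In this assay compound 3 gives 39000 nM, the first real number among the compounds shown, and it comes from a change on the saturated ring carbon next to the ring oxygen, not from the aromatic chloro change, whose step cannot be read. Cyano in place of methoxycarbonyl gives an at least 1.5-fold lower number from compound 2 to compound 3 (0.18 log units; that floor lies within the scatter), so this position is the first place where a step has a readable floor, though that floor does not clear the usual scatter. The other values shown remain limits and not numbers: the limit of > 60000 nM in this assay, at which 2 of the 3 values shown sit.

The true size of the step stays open, and the compounds shown cannot tell whether cyano would also give a number in the core of compound 1, with hydrogen in place of chloro on the aromatic carbon. Going by these compounds, it also remains open what a carboxylic acid, a primary amide or an aminomethyl group on this saturated ring carbon would give in this assay, and so whether any group here can move the number clearly beyond the scatter.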